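Ring-nitrogen substituent series: compound 3 to compound 4

The source may hold more compounds than are shown below. What is called first, only, known or untested is meant among the compounds shown, and "the series" means these compounds.

Going by the values given here, compound 3 `CN1C(=S)[C@@H](NC(=O)c2nc(Cc3ccccc3)n(C3CCC3)n2)COc2ccccc21` gives 181 nM in a functional assay on HT-29 cells (Homo sapiens) for inhibition, read by luminescence and CellTiter-Glo, with a stated time of 24 h (a lower number here means that less compound is needed, a higher number that more compound is needed for the effect), the lowest of the three numbers so far; compound 2 `CN1C(=S)[C@@H](NC(=O)c2nc(Cc3ccccc3)n(CCC(F)(F)F)n2)COc2ccccc21` gives 1550 nM and compound 1 `CN1C(=S)[C@@H](NC(=O)c2nc(Cc3ccccc3)n(CCCF)n2)COc2ccccc21` gives 4760 nM. Both steps onto the aromatic nitrogen ended at compound 3: a 26-fold lower number from compound 1 to compound 3 (1.42 log units; beyond the scatter) and an 8.6-fold lower number from compound 2 to compound 3 (0.93 log units; beyond the scatter); the remaining step, a 3.1-fold lower number from compound 1 to compound 2 (0.49 log units; beyond the scatter), lies between the two open chains. Compound 4 `CN1C(=S)[C@@H](NC(=O)c2nc(Cc3ccccc3)n(CC3CCOCC3)n2)COc2ccccc21` carries (oxan-4-yl)methyl in place of cyclobutyl on an aromatic nitrogen. Among the compounds with values here, no measured step exchanges cyclobutyl for a ring-bearing chain, so the two bearing steps show only that both open chains gave higher numbers than cyclobutyl. The number for compound 4 is therefore expected to rise modestly, a 2.8-fold higher number from compound 3 to compound 4 (0.44 log units; beyond the scatter). Compound 4 is estimated at 500 nM, with a range from 150 nM to 2000 nM.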

Compound 4, half-maximal effective concentration: 6310 nM
For compound 4 the middle estimate is 13-fold (1.10 log units) below the measured one; the whole stated range lies below it.
By their numbers in this assay, from the lowest: compound 3; then compound 2; then compounds 1 and 4 (each within the scatter of the next).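

In this assay the (oxan-4-yl)methyl group on the aromatic nitrogen does not keep the level of cyclobutyl, with a 35-fold higher number from compound 3 to compound 4 (1.54 log units; beyond the scatter) as the step, so carrying a ring on this nitrogen does not by itself give a low number. Compound 4 also stands with the open chains rather than with compound 3: the steps are a 4.1-fold higher number from compound 2 to compound 4 (0.61 log units; beyond the scatter) and a 1.3-fold higher number from compound 1 to compound 4 (0.12 log units; within the scatter) in this series.

As far as these compounds go, whether cyclopropyl, cyclopentyl or an isopropyl group would hold the number of compound 3 stays open. Nothing available accounts for the size of these steps.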